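The source may report more compounds than this note shows. Statements on the series, on what has been measured and on what is new or still open speak of the compounds shown alone.

Within the data shown here, compound 2 `CO[C@@H]1[C@H](N(C)C(N)=O)C[C@H]2O[C@]1(C)n1c3ccccc3c3c4c(c5c6ccccc6n2c5c31)C(=O)NC4` carries the larger of the two numbers measured so far, though its step from compound 1 lies within the scatter: in an assay on isolated protein for inhibition of protein kinase C theta type (Homo sapiens), read by HTRF (on this read-out lower numbers stand for stronger inhibition and higher numbers for weaker inhibition), compound 2 gives 400 nM, while compound 1 `CO[C@@H]1[C@H](N(C)C=O)C[C@H]2O[C@]1(C)n1c3ccccc3c3c4c(c5c6ccccc6n2c5c31)C(=O)NC4` gives 250 nM. Among the measured compounds shown here, the only measured step, a 1.6-fold higher number from compound 1 to compound 2 (0.20 log units; within the scatter), is within the scatter. Compound 3 `CO[C@@H]1[C@H](NC(C)=O)C[C@H]2O[C@]1(C)n1c3ccccc3c3c4c(c5c6ccccc6n2c5c31)C(=O)NC4` differs from compound 2 by acetamido in place of carbamoyl(methyl)amino on a saturated ring carbon. For the measured compounds named here, no measured step matches this change, and the one step available, a 1.6-fold higher number from compound 1 to compound 2 (0.20 log units; within the scatter), left the number essentially unmoved. The expected step, a 1.3-fold lower number from compound 2 to compound 3 (0.10 log units; within the scatter), is therefore none beyond the scatter. For compound 3 the estimate is 320 nM, in a range from 110 nM to 950 nM.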

Compound 3, half-maximal inhibitory concentration: 38 nM
Estimate against measurement, compound 3: 8.4-fold (0.93 log units) above, and the stated range ends above it.
By their numbers in this assay, from the lowest: compound 3; then compounds 1 and 2 (each within the scatter of the next).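

At this position on the saturated ring carbon, the group clearly matters, although the earlier change on the carbonyl carbon stayed within the scatter. In this assay, acetamido in place of carbamoyl(methyl)amino gives an 11-fold lower number from compound 2 to compound 3 (1.02 log units; beyond the scatter), and in place of formyl(methyl)amino it gives a 6.6-fold lower number from compound 1 to compound 3 (0.82 log units; beyond the scatter). Nothing available explains this difference.
The compounds shown leave open whether acetyl(methyl)amino would read like compound 3 or like compounds 1 and 2. They also leave open how a plain amine or a longer acyl chain would read here.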